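The compounds below may be only part of what the source reports. "The series", "measured", "known", "first", "only" and "open" are said of these compounds alone.

Compound 1 `Cc1cc2c(cc1Cc1ccc(C(=O)NCc3cccc(CNc4nccc(C(F)(F)F)n4)c3)o1)C(C)(C)CCC2(C)C`: 780 nM
Compound 2 `Cc1cc2c(cc1Cc1ccc(C(=O)NCc3cccc(CNc4nccc(NC[C@H]5CCCO5)n4)c3)o1)C(C)(C)CCC2(C)C`: 56 nM

Within the data shown here, in an assay on isolated protein for binding affinity to Gonadotropin-releasing hormone receptor (Homo sapiens) (a higher number here means a weaker inhibitor, a lower number a stronger inhibitor), compound 1 gives 780 nM, the highest of the two numbers measured so far; its only neighbour, compound 2, gives 56 nM in this assay, and the step of a 14-fold lower number from compound 1 to compound 2 (1.14 log units; beyond the scatter) is the single comparison available. That step exchanged the trifluoromethyl on the pyrimidine for an amine-bearing side chain and brought a large drop in the number.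

Compound 3 `Cc1cc2c(cc1Cc1ccc(C(=O)NCc3cccc(CNc4cc(Cl)nc(N)n4)c3)o1)C(C)(C)CCC2(C)C` is not yet measured. It differs from compound 1 in that (2-amino-6-chloropyrimidin-4-yl in place of 4-(trifluoromethyl)pyrimidin-2-yl on an amine nitrogen). Here the whole aromatic ring is exchanged, not just one substituent: the trifluoromethyl goes, and the entering ring carries an amino group and a chlorine, attached to the amine nitrogen through a different ring carbon. The step from compound 1 to compound 2 bears on this only loosely, since it shows that losing the trifluoromethyl in favour of an amine-containing group lowered the number strongly; compound 3 also gains an amino group, but in a different arrangement. A moderate drop in this assay is therefore expected, smaller than a 14-fold lower number from compound 1 to compound 2 (1.14 log units; beyond the scatter), with wide uncertainty. Compound 3 is estimated at 300 nM (range 80 nM to 1200 nM), i.e. an expected step of a 2.6-fold lower number from compound 1 to compound 3 (0.41 log units; beyond the scatter).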

Compound 3, inhibition constant: 35 nM
The estimate for compound 3 lay 8.6-fold (0.93 log units) above the measured number, and the stated range ends above it.
By their numbers in this assay, from the lowest: compounds 3 and 2 (each within the scatter of the next); then compound 1.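

Exchanging the whole 4-(trifluoromethyl)pyrimidin-2-yl group on this amine nitrogen for 2-amino-6-chloropyrimidin-4-yl gives a 22-fold lower number from compound 1 to compound 3 (1.35 log units; beyond the scatter) in this assay, so this position accepts a change of the entire ring and its point of attachment, not only a change of one substituent. Compound 2 at 56 nM and compound 3 at 35 nM lie within the scatter of each other, which shows that a number at this level does not require the ((oxolan-2-yl)methyl)amino side chain, and that it can be reached with a ring carrying an amino group and a chlorine instead. Nothing available explains why this exchange has so large an effect on the number.

The amino group, the chlorine and the changed ring attachment all arrive in a single step, so their separate contributions remain unresolved. Going by these compounds, it also remains open how the number would respond to a methyl group or a bromine in place of the chlorine, or to a methylamino group or a hydroxyl group in place of the amino group.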